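Adding a Third Methoxy Group to a Sulfonamide Pyrazoline

The source may report more compounds than this note shows. Statements on the series, on what has been measured and on what is new or still open speak of the compounds shown alone.

Measured so far:
compound 1, `Cc1cc(O)c(C2=NN(c3ccc(S(N)(=O)=O)cc3)C(c3ccccc3Cl)C2)cc1Cl`, 1590 nM
compound 2, `COc1ccc(C2CC(c3cc(Cl)c(C)cc3O)=NN2c2ccc(S(N)(=O)=O)cc2)cc1OC`, 2700 nM

Both compounds were tested in a functional assay on SF-295 cells (Homo sapiens) for antiproliferative activity, with a stated time of 48 h; a higher number here means a weaker inhibitor of growth, a lower number a stronger inhibitor of growth. Compound 1 gives 1590 nM and compound 2 gives 2700 nM. Among the measured compounds shown here, the only measured step, a 1.7-fold higher number from compound 1 to compound 2 (0.23 log units; within the scatter), is a swap of the aryl group on the saturated ring carbon, and it lies within the scatter, so on these two numbers compound 2 stands apart from compound 1 by no more than repeat measurements would.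

Compound 3, `COc1ccc(C2CC(c3cc(Cl)c(C)cc3O)=NN2c2ccc(S(N)(=O)=O)cc2)c(OC)c1OC`, has not yet been measured in this assay. It differs from compound 2 in one place: methoxy in place of hydrogen on an aromatic carbon. For the measured compounds named here, no measured step touches this kind of change; the one step that exists concerns a different aryl group and was itself within the scatter. There is therefore nothing to argue for a step in either direction beyond the scatter, and the expectation is no change at the digits printed from compound 2 to compound 3 (within the scatter). In this assay compound 3 is estimated at 2700 nM, with a range from 900 nM to 8000 nM.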

Compound 3, concentration for 50% growth inhibition: 1800 nM
The estimate for compound 3 lay 1.5-fold (0.18 log units) above the measured number, and the stated range covers the measured number.
By their numbers in this assay, from the lowest: compounds 1, 3 and 2 (each within the scatter of the next).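

In this assay, a methoxy group on an aromatic carbon, ortho to a large group and ortho to a methoxy group, turns 3,4-dimethoxyphenyl into 2,3,4-trimethoxyphenyl and gives a 1.5-fold lower number from compound 2 to compound 3 (0.18 log units; within the scatter), so this crowded position accepts a third methoxy group without any shift that can be told apart from repeat measurement. Set against the 2-chlorophenyl group on the same saturated ring carbon, the 2,3,4-trimethoxyphenyl group gives a 1.1-fold higher number from compound 1 to compound 3 (0.05 log units; within the scatter), which means that all three aryl groups shown at that carbon now lie within the scatter of one another in this assay. No measurement is at hand that speaks to why these numbers sit so close together.

The aryl groups shown carry only chlorine or methoxy groups, so it remains open whether an amine, a carboxylic acid or a longer alkoxy chain at this same aromatic carbon would give a step beyond the scatter. These three numbers also come from a single cell line, and they leave open whether the same closeness would hold in other cells.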